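Methoxy in place of hydrogen: one precedent in the series

The source may report more compounds than this note shows. Statements on the series, on what has been measured and on what is new or still open speak of the compounds shown alone.

Compound 1 `COc1ccc(-c2cc(/C=C/C(=O)c3ccc(N)cc3)[nH]n2)cc1` and compound 3 `COc1ccc(-c2cc(/C=C/C(=O)c3ccc(N)cc3)[nH]n2)cc1OC` share a core and differ in one place: methoxy in place of hydrogen on an aromatic carbon. In a functional assay on OVCAR-4 cells (Homo sapiens) for cytotoxicity, read by sulforhodamine B assay, with a stated time of 48 h, tested at 1 uM (a higher number here means a weaker effect of the compound at the concentration tested, a lower number a stronger effect), compound 1 gives 52%, and compound 3 gives 69%. The step is a number 17 percentage points higher from compound 1 to compound 3 (beyond the scatter). Compound 2 `COc1ccc(C(=O)/C=C/c2cc(-c3cc(OC)c(OC)c(OC)c3)n[nH]2)cc1OC` has the same pieces arranged differently; the difference between its core and that of compound 1 is not broken down here. In this assay compound 2 gives 70%, which lies within the scatter of compound 3 and beyond the scatter relative to compound 1.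

Compound 4 `COc1cc(C(=O)/C=C/c2cc(-c3cc(OC)c(OC)c(OC)c3)n[nH]2)cc(OC)c1OC` is not yet measured. It arises from compound 2 by methoxy in place of hydrogen on an aromatic carbon. Among the compounds here this structural change occurs twice, from compound 1 to compound 3 and from compound 2 to compound 4. It is the same kind of change, not the same: in compound 4 the entering methoxy is also meta to a methoxy group, which is not so for compound 3. The expectation therefore rests on a single precedent, a number 17 percentage points higher from compound 1 to compound 3 (beyond the scatter), and on the fact that compound 2 already gives 70% on a percentage read-out. In this assay the expected step is a number 10 percentage points higher from compound 2 to compound 4 (within the scatter). Compound 4 is estimated at 80%, with a range from 65% to 93%.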

Compound 4, a percentage reported as activity, at one concentration (the size of the read-out at that concentration, not a potency): 79%
For compound 4 the middle estimate is 1 percentage points above the measured one, within the range that was stated.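

In this assay, methoxy in place of hydrogen on an aromatic carbon gives a number 9 percentage points higher from compound 2 to compound 4 (within the scatter), so on the core of compound 2 this step cannot be told apart from repeat measurement. Set beside the earlier step on the core of compound 1, the size of the step does not separate the two cores: the same change on two cores in this assay, a number 17 percentage points higher (beyond the scatter) from compound 1 to compound 3 and a number 9 percentage points higher (within the scatter) from compound 2 to compound 4, 8 percentage points apart, within the scatter of two such steps. Among the compounds shown here, this shows that the two steps are compatible with one another, but it does not establish a common step size or show that the change transfers to any other core, since only two pairs are available, only the step on the core of compound 1 lies beyond the scatter, and each read-out comes from a single concentration and is not a potency.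

The compounds shown leave open how a hydroxyl group, a fluorine atom or a longer chain such as ethoxy would read in place of methoxy on these aromatic carbons. They also leave open whether the step keeps its size on a core carrying a carboxylic acid in place of the amine of compound 1 and compound 3.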